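The source may hold more compounds than are shown below. What is called first, only, known or untested is meant among the compounds shown, and "the series" means these compounds.

In a functional assay on HT-29 cells (Homo sapiens) for cytotoxicity, read by MTT assay, with a stated time of 24 h, tested at 32 ug/mL (on this read-out lower numbers stand for a weaker effect and higher numbers for a stronger effect at the one concentration tested), compound 1 `Cn1c(-c2ccc(NC(=O)CCl)cc2)nc(-c2ccccc2)c1-c1ccccc1` gives 53.2%. Compound 2 `Cn1cnnc1SCC(=O)Nc1ccc(-c2nc(-c3ccccc3)c(-c3ccccc3)n2C)cc1` gives 86.1%, and compound 3 `Cn1nnnc1SCC(=O)Nc1ccc(-c2nc(-c3ccccc3)c(-c3ccccc3)n2C)cc1` gives 84%, which places compound 3 second highest of the three numbers, with compound 2 within the scatter of it and compound 1 far below. The steps of a number 32.9 percentage points higher from compound 1 to compound 2 (beyond the scatter) and a number 30.8 percentage points higher from compound 1 to compound 3 (beyond the scatter) were both large, whereas the ring swap on the sulfur, a number 2.1 percentage points lower from compound 2 to compound 3 (within the scatter), stayed within the scatter. Compound 4 `Cn1ccnc1SCC(=O)Nc1ccc(-c2nc(-c3ccccc3)c(-c3ccccc3)n2C)cc1` carries the change (1-methyl-1H-imidazol-2-yl in place of 1-methyl-1H-tetrazol-5-yl on a sulfur). Going by the values given here, the only step that bears on this, a number 2.1 percentage points lower from compound 2 to compound 3 (within the scatter), was within the scatter, so no step beyond the scatter is expected in this assay for compound 4. Compound 4 is therefore estimated at 82%, between 65% and 95%. That estimate means an expected step of a number 2 percentage points lower from compound 3 to compound 4 (within the scatter).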

Compound 4, a percentage reported as activity, at one concentration (the size of the read-out at that concentration, not a potency): 41.1%
Compound 4: the middle estimate sits 40.9 percentage points above what was measured; measured number outside the range, below it.
By their numbers in this assay, from the lowest: compound 4; then compound 1; then compounds 3 and 2 (each within the scatter of the next).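

The ring on the sulfur matters after all in this assay: the 1-methyl-1H-imidazol-2-yl group gives a number 42.9 percentage points lower from compound 3 to compound 4 (beyond the scatter) and a number 45 percentage points lower from compound 2 to compound 4 (beyond the scatter), although the two rings compared earlier could not be told apart. Replacing chloro with a ring-bearing sulfanyl group therefore does not raise the number in every case, since a number 12.1 percentage points lower from compound 1 to compound 4 (beyond the scatter) runs against the gains seen for the other two rings. Nothing available explains this drop. The compounds shown leave open how a phenyl or a 1,3-thiazol-2-yl group on the sulfur would behave. They also leave open whether an amine in place of the sulfanyl group would keep the number of compound 2 or fall towards that of compound 4.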